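The source may hold more compounds than are shown below. What is called first, only, known or untested is meant among the compounds shown, and "the series" means these compounds.

Series notes. Two compounds carry numbers in a functional assay on 786-0 cells (Homo sapiens) for inhibition, read by sulforhodamine B assay, with a stated time of 48 h, tested at 10 uM; a higher number here means more inhibition at the concentration tested (going by the name of the read-out), a lower number less inhibition. Compound 1 `c1ccc2c(-c3cn4ccnc4c(-c4ccc5ncn(C6CCCCC6)c5c4)n3)cccc2c1` gives 6.33% in this assay, while compound 2 `Cc1cccc(-c2cn3ccnc3c(-c3ccc4ncn(Cc5ccccc5)c4c3)n2)c1` gives 21.5%. On these two numbers compound 2 stands highest; its nearest neighbour is compound 1, whose value lies lower by a gap beyond the usual scatter of repeated measurements. Compound 3 `c1ccc(Cn2cnc3ccc(-c4nc(-c5cccc6ccccc56)cn5ccnc45)cc32)cc1` has not yet been measured in this assay. The change from compound 2 to compound 3 is naphthalen-1-yl in place of 3-methylphenyl on an aromatic carbon. Among the measured compounds shown here, no step between measured compounds isolates this change, so its size is not known directly. For the measured compounds named here, the only pointer is compound 1, which also carries a naphthalen-1-yl group and gives 6.33% in this assay, the lower of the two numbers. The step from compound 2 to compound 3 in this assay is therefore expected to be downward, estimated at a number 9.5 percentage points lower from compound 2 to compound 3 (within the scatter), a size near the edge of the usual scatter rather than clearly beyond it. Compound 3 is expected to give 12% in this assay, with a range from 2% to 28%.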

Compound 3, a percentage reported as inhibition, at one concentration (the size of the read-out at that concentration, not a potency): 12.4%
For compound 3 the middle estimate is 0.4 percentage points below the measured one; the measured number falls inside the stated range.
By their numbers in this assay, from the lowest: compounds 1, 3 and 2 (each within the scatter of the next, the first and the last beyond it).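

Among the compounds shown here, compound 3 gives the first direct reading at the aromatic carbon next to the ring nitrogen: in this assay, naphthalen-1-yl in place of 3-methylphenyl comes to a number 9.1 percentage points lower from compound 2 to compound 3 (within the scatter) and so does not separate from the scatter, even with two carbon-only aromatic rings entering for one. For the compounds shown here, compound 3 also gives the first reading at the aromatic nitrogen of the shared core, where benzyl in place of cyclohexyl comes to a number 6.1 percentage points higher from compound 1 to compound 3 (within the scatter) in this assay, so neither single change stands clear of the scatter on its own. Nothing measured on these compounds accounts for the size of either step.

Going by these compounds, all three compounds carry only carbon-built groups at these two places, so it remains open how this assay responds to an amine or a carboxylic acid on the aromatic ring at the carbon, or to a longer chain in place of benzyl on the nitrogen. These readings come from a single concentration and are not potencies, so any real difference hidden within the scatter between neighbouring compounds also stays unresolved.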